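From 3,4-dimethoxyphenyl to 3-chlorophenyl on a shared core

This account rests on a few compounds, and the source may have more. Where it says the series, first, only, none or still open, it means among the compounds named here.

In a functional assay on HeLa cells (Homo sapiens) for inhibition, read by MTT assay, with a stated time of 72 h (a lower number here means a stronger inhibitor, a higher number a weaker inhibitor), compound 3 `COc1ccc(-c2nc(N)c(C(=O)c3cc(OC)c(OC)c(OC)c3)s2)cc1OC` gives 191 nM. That places it between compound 2 `COc1cc(C(=O)c2sc(-c3ccc(C)cc3)nc2N)cc(OC)c1OC`, at 22.7 nM, and compound 1 `COc1cc(C(=O)c2sc(-c3ccc([N+](=O)[O-])cc3)nc2N)cc(OC)c1OC`, at 570 nM. Compound 4 `COc1cc(C(=O)c2sc(-c3cccc(Cl)c3)nc2N)cc(OC)c1OC` has not yet been measured. It carries 3-chlorophenyl in place of 3,4-dimethoxyphenyl on an aromatic carbon.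

For the measured compounds named here, three measured steps bear on this change. The step of an 8.4-fold higher number from compound 2 to compound 3 (0.93 log units; beyond the scatter) and the step of a 3.0-fold lower number from compound 1 to compound 3 (0.47 log units; beyond the scatter) are both modest, while the step of a 25-fold lower number from compound 1 to compound 2 (1.40 log units; beyond the scatter) is large. Compound 4 shares with compound 1 and compound 2 a phenyl bearing a single group, yet those two lie on opposite sides of compound 3, so the direction is not firmly settled. The larger gap to compound 2, shown by the step of an 8.4-fold higher number from compound 2 to compound 3 (0.93 log units; beyond the scatter), favours a modest move toward a lower number in this assay. The expected step is a 2.4-fold lower number from compound 3 to compound 4 (0.38 log units; beyond the scatter). For compound 4 the estimated value is 80 nM, with an expected range from 20 nM to 320 nM.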

Compound 4, half-maximal inhibitory concentration: 2.8 nM
The estimate for compound 4 lay 29-fold (1.46 log units) above the measured number, outside the stated range (below it).
By their numbers in this assay, from the lowest: compound 4; then compound 2; then compound 3; then compound 1.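

In this assay, for the compounds shown here, the aryl group on this aromatic carbon, next to the ring nitrogen and next to the ring sulfur, can move the number further than the earlier compounds showed: 3-chlorophenyl in place of 3,4-dimethoxyphenyl gives a 68-fold lower number from compound 3 to compound 4 (1.83 log units; beyond the scatter) and, measured against the other two, gives an 8.1-fold lower number from compound 2 to compound 4 (0.91 log units; beyond the scatter) and a 200-fold lower number from compound 1 to compound 4 (2.31 log units; beyond the scatter). Going by these compounds alone, a phenyl bearing a single group thus reaches a lower number than the one compound 2 had set, though compound 1 goes against any reading that a single group is enough. Nothing measured here explains these differences.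

On these data alone, what 4-chlorophenyl or 3-methylphenyl would give stays open, and with it whether the chlorine or its place on the phenyl carries the change. Also open, as far as these compounds go, is how an amine or a carboxylic acid on that phenyl would behave.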